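This account rests on a few compounds, and the source may have more. Where it says the series, first, only, none or still open, it means among the compounds named here.

Measured in an ADME assay on MT4 cells (Homo sapiens) for cytotoxicity, read by MTT assay; on this read-out higher numbers stand for lower toxicity in this test and lower numbers for higher toxicity in this test:
Compound 1 `CCCCCCCCCNC(=O)C1C(=O)N(O)C(=O)c2ccccc21` gives 88500 nM
Compound 2 `CCCCCNC(=O)C1C(=O)N(O)C(=O)c2ccccc21` gives 130000 nM
Compound 3 `O=C(NC1CCCC1)C1C(=O)N(O)C(=O)c2ccccc21` gives > 250000 nM (a limit of the assay, not a number)

Compound 3 stands at the limit of > 250000 nM in this assay, at which 1 of the 3 values shown sits, and so has only a limit, with no exact number. The next compound to be measured is compound 4 `CCCCCCCCNC(=O)C1C(=O)N(O)C(=O)c2ccccc21` and it differs from compound 3 in one place octyl in place of cyclopentyl on an amide-type nitrogen with octyl in place of cyclopentyl on an amide-type nitrogen.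

Going by the values given here, two measured steps bear on this change. The first swaps a chain for the ring, the reverse of what happens here, and shows an at least 1.9-fold higher number from compound 2 to compound 3 (0.28 log units; that floor lies within the scatter) with a floor that stays within the scatter. The second shortens the chain and shows a 1.5-fold higher number from compound 1 to compound 2 (0.17 log units; within the scatter) so that the two chain compounds cannot be told apart. The chain of compound 4 lies in length between those of compound 2 (130000 nM) and compound 1 (88500 nM), so its number is expected to fall close to theirs. That means a lower number than the limit, a modest drop that may not clear the scatter by much. As far as these compounds go, the estimated change is an at least 2.5-fold lower number from compound 3 to compound 4 (0.39 log units; beyond the scatter) in this assay and its true size stays open while one end is only a limit. For compound 4 the estimated value is 100000 nM (expected range 60000 nM to 170000 nM).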

Compound 4, half-maximal cytotoxic concentration: 98500 nM
Estimate against measurement, compound 4: 1.0-fold (0.01 log units) above; the measured number falls inside the stated range.
By their numbers in this assay, from the lowest: compounds 1, 4 and 2 (each within the scatter of the next). At a limit, above all of these: compound 3.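

In this assay, going by these compounds alone, octyl in place of cyclopentyl on the amide-type nitrogen gives an at least 2.5-fold lower number from compound 3 to compound 4 (0.40 log units; beyond the scatter), the first step at this position that clears the scatter and so the first sign that the open chain and the ring can be told apart, with the chain on the more toxic side in this test. Compound 3 has only a limit of the assay and no exact number, so this step gives a floor and not a true size: the limit of > 250000 nM in this assay, at which 1 of the 4 values shown sits.

Among the open chains, length makes no readable difference over this span, with a 1.3-fold lower number from compound 2 to compound 4 (0.12 log units; within the scatter) and a 1.1-fold higher number from compound 1 to compound 4 (0.05 log units; within the scatter), so the pentyl, octyl and nonyl compounds cannot be told apart.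

As far as these compounds go, what remains open is how far compound 3 really lies from these chains, and whether the gap holds for other rings. A cyclohexyl group on the same nitrogen, a much longer chain, or a chain ending in an amine or a carboxylic acid could each show whether the pattern extends beyond these four compounds.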